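A few compounds are considered here, and "the series" means these few. Any claim that something is new, unique, unknown or untested is made for them only; others in the source may bear on it.

In a functional assay on MIA PaCa-2 cells (Homo sapiens) for cytotoxicity, read by MTT assay, with a stated time of 4 h (a lower number here means a stronger inhibitor, a higher number a weaker inhibitor), compound 1 (`COC1=CC(=O)c2c(COc3ccc([N+](=O)[O-])cc3)c(C)n(C)c2C1=O`) gives 638 nM, compound 2 (`COC1=CC(=O)c2c(COc3ccc(C#N)cc3)c(C)n(C)c2C1=O`) gives 463 nM and compound 3 (`COC1=CC(=O)c2c(COc3ccc(C(F)(F)F)cc3)c(C)n(C)c2C1=O`) gives 496 nM on the same scale. Compound 2 stands with the other two rather than apart from them, as all three measured steps lie within the scatter (a 1.4-fold lower number from compound 1 to compound 2 (0.14 log units; within the scatter); a 1.1-fold higher number from compound 2 to compound 3 (0.03 log units; within the scatter); a 1.3-fold lower number from compound 1 to compound 3 (0.11 log units; within the scatter)). Still unmeasured is compound 4 (`COC1=CC(=O)c2c(COc3ccncc3)c(C)n(C)c2C1=O`), which carries pyridin-4-yl in place of 4-cyanophenyl on an oxygen on a saturated carbon. The three steps bear on this change only loosely: each swaps a group on an aromatic carbon, and none replaces the aromatic ring itself. No measurement here shows what such a ring change does, so the range must stay wide. Taking compound 2 (463 nM) and its small steps as the guide, no step beyond the scatter is expected in this assay for this change. The estimated step is small (a 1.3-fold higher number from compound 2 to compound 4 (0.11 log units; within the scatter)). For compound 4 the expected value is an estimated 600 nM (expected range 200 nM to 1800 nM).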

Compound 4, half-maximal inhibitory concentration: 2560 nM
Estimate against measurement, compound 4: 4.3-fold (0.63 log units) below; the whole stated range lies below it.
By their numbers in this assay, from the lowest: compounds 2, 3 and 1 (each within the scatter of the next); then compound 4.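

In this assay, putting pyridin-4-yl in place of 4-cyanophenyl on the oxygen gives a 5.5-fold higher number from compound 2 to compound 4 (0.74 log units; beyond the scatter) and so shows that this part of the molecule can shift the number. The earlier swaps among nitro, cyano and trifluoromethyl, all within the scatter, did not show this. The new step changes the ring atoms and removes the nitrile together, and the compounds shown cannot separate these two changes, nor does any measurement at hand explain the result.

Going by these compounds, it remains open whether an unsubstituted phenyl ring, which would keep the all-carbon ring without the nitrile, would give a number closer to that of compound 2 or that of compound 4. On these data alone, the effects of a pyridin-3-yl ring, or of an amine on the phenyl ring, also remain open.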